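A few compounds are considered here, and "the series" means these few. Any claim that something is new, unique, unknown or untested is made for them only; others in the source may bear on it.

Three analogues have been measured in a functional assay on MCF7 cells (Homo sapiens) for cytotoxicity; on this read-out lower numbers stand for stronger inhibition and higher numbers for weaker inhibition. Compound 1 `COc1ccc(Cn2cc(/C=N\NC(=O)c3c[nH]c4ccccc34)c3cc(OC)ccc32)cc1` gives 15000 nM; compound 2 `COc1ccc(Cn2cc(/C=N\NC(=O)c3c[nH]c4ccc(Br)cc34)c3cc(OC)ccc32)cc1` gives 3100 nM; compound 3 `COc1ccc(Cn2cc(/C=N\NC(=O)c3c[nH]c4ccc(Br)cc34)c3ccc(F)cc32)cc1` gives 31700 nM. Compound 3 stands highest of the three. Among the measured compounds shown here, the one counted change within this set is hydrogen in place of bromo on an aromatic carbon, and it made a 4.8-fold higher number from compound 2 to compound 1 (0.68 log units; beyond the scatter). How the cores of compound 2 and compound 3 differ is not broken down here; their two values simply show compound 3 the higher of the pair. For the measured compounds named here, compound 4 `COc1ccc(Cn2cc(/C=N\NC(=O)c3c[nH]c4ccccc34)c3ccc(F)cc32)cc1` is not yet measured; it derives from compound 3 through (hydrogen in place of bromo on an aromatic carbon), the same change at the same place as the one from compound 2 to compound 1. Going by the values given here, from compound 3 to compound 4 the expected step in this assay is a 3.8-fold higher number from compound 3 to compound 4 (0.58 log units; beyond the scatter), close to the earlier one, resting on the single precedent a 4.8-fold higher number from compound 2 to compound 1 (0.68 log units; beyond the scatter) with no second instance to check how it carries onto the core of compound 3. Compound 4 is accordingly estimated at 120000 nM, between 45000 nM and 320000 nM, a number high enough that the assay may report only a limit.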

Compound 4, half-maximal inhibitory concentration: 13100 nM
For compound 4 the middle estimate is 9.2-fold (0.96 log units) above the measured one, and the stated range ends above it.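

In this assay, hydrogen in place of bromo gives a 2.4-fold lower number from compound 3 to compound 4 (0.38 log units; beyond the scatter), so the change does not carry from the core of compound 2 to the core of compound 3 in either size or direction: the same change on two cores in this assay, a 4.8-fold higher number (0.68 log units; beyond the scatter) from compound 2 to compound 1 and a 2.4-fold lower number (0.38 log units; beyond the scatter) from compound 3 to compound 4, 12-fold (1.07 log units) apart, beyond the scatter of two such steps Within these two pairs, the outcome of replacing 5-bromo-1H-indol-3-yl with 1H-indol-3-yl depends on the core, and a step read on one core is not a usable forecast for the other. Among the compounds shown here, with only one pair per core, the data do not show which difference between the cores is responsible, nor which direction a further core would follow.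

Open, going by these compounds, is whether other groups on the same aromatic carbon, such as chloro, methoxy or a nitrile, would also change direction between the two cores. Also open, on these data alone, is how the same change would behave on a core carrying chloro or plain hydrogen at the place where the cores of compound 1 and compound 4 differ.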